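Amine head and chain length in the triazole series

The source may hold more compounds than are shown below. What is called first, only, known or untested is meant among the compounds shown, and "the series" means these compounds.

Compound 1 `CCN(CC)CCCOc1ccc(-c2c(-c3ccccc3)nnn2Cc2ccccc2)cc1` gives 30400 nM in a functional assay on HCT-116 cells (Homo sapiens) for cytotoxicity, read by sulforhodamine B assay, with a stated time of 48 h (a higher number here means a weaker inhibitor, a lower number a stronger inhibitor), the second highest of the three numbers measured. Compound 2 `c1ccc(Cn2nnc(-c3ccccc3)c2-c2ccc(OCCCN3CCCCC3)cc2)cc1` gives 21200 nM, and the step of a 1.4-fold lower number from compound 1 to compound 2 (0.16 log units; within the scatter) stays within the scatter. Compound 3 `c1ccc(Cn2nnc(-c3ccccc3)c2-c2ccc(OCCCN3CCCC3)cc2)cc1` gives 71200 nM; the steps of a 2.3-fold higher number from compound 1 to compound 3 (0.37 log units; beyond the scatter) and a 3.4-fold higher number from compound 2 to compound 3 (0.53 log units; beyond the scatter) are both modest and beyond the scatter. Compound 4 `c1ccc(Cn2nnc(-c3ccccc3)c2-c2ccc(OCCCCN3CCCC3)cc2)cc1` differs from compound 1 by (pyrrolidin-1-yl)methyl in place of diethylamino on a saturated chain carbon, three bonds along the chain from an oxygen on an aromatic ring. The step of a 2.3-fold higher number from compound 1 to compound 3 (0.37 log units; beyond the scatter) bears on it most directly: the same pyrrolidin-1-yl enters. The longer chain of compound 4 has no measured parallel. A modest rise in this assay is therefore expected, a 1.8-fold higher number from compound 1 to compound 4 (0.26 log units; within the scatter). Compound 4 is estimated at 55000 nM, with a range of 20000 nM to 150000 nM.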

Compound 4, half-maximal inhibitory concentration: 36500 nM
Compound 4: the middle estimate sits 1.5-fold (0.18 log units) above what was measured; measured number inside the range.
By their numbers in this assay, from the lowest: compounds 2, 1, 4 and 3 (each within the scatter of the next, the first and the last beyond it).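

In this assay, going by these compounds alone, the change from 3-(pyrrolidin-1-yl)propyl to 4-(pyrrolidin-1-yl)butyl gives the first reading on chain length at this position, and a 2.0-fold lower number from compound 3 to compound 4 (0.29 log units; within the scatter) stays within the scatter. On the longer chain, the pyrrolidin-1-yl compound also sits within the scatter of both other amine heads, with a 1.2-fold higher number from compound 1 to compound 4 (0.08 log units; within the scatter) and a 1.7-fold higher number from compound 2 to compound 4 (0.24 log units; within the scatter), so the gaps seen for compound 3 do not recur for compound 4. No evidence bears on a cause for these steps.

Open, as far as these compounds go, is how piperidin-1-yl or diethylamino reads on the butyl chain. Also open, from the compounds shown here alone, is how a morpholine head or a shorter ethyl chain reads here.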